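This account rests on a few compounds, and the source may have more. Where it says the series, first, only, none or still open, it means among the compounds named here.

Compound 3 `CCCCCNc1cccc2c(S(=O)(=O)Nc3onc(C)c3C)cccc12` gives 80 nM in an assay on VSM-A10 cells for antagonist activity at Endothelin-1 receptor (Rattus norvegicus); on this read-out lower numbers stand for stronger inhibition and higher numbers for weaker inhibition. Among the three measured compounds it stands second highest: its nearest neighbour is compound 2 `CNc1cccc2c(S(=O)(=O)Nc3onc(C)c3C)cccc12`, which gives 130 nM, a gap within the scatter, while compound 1 `Cc1noc(NS(=O)(=O)c2cccc3c(NC(C)C)cccc23)c1C`, which gives 20 nM, lies furthest away, a 4.0-fold higher number from compound 1 to compound 3 (0.60 log units; beyond the scatter). Compound 4 `Cc1noc(NS(=O)(=O)c2cccc3c(CN(C)C)cccc23)c1C` differs from compound 3 by (dimethylamino)methyl in place of pentylamino on an aromatic carbon. The measured steps all vary only the alkyl group on a nitrogen on an aromatic ring: a 6.5-fold higher number from compound 1 to compound 2 (0.81 log units; beyond the scatter), a 4.0-fold higher number from compound 1 to compound 3 (0.60 log units; beyond the scatter) and a 1.6-fold lower number from compound 2 to compound 3 (0.21 log units; within the scatter). Going by the values given here, none of them changes the attachment to the ring or takes away the hydrogen-bond donor, so no measured step bears directly on the change to compound 4. Those alkyl variations were modest or within the scatter, and the new group is a larger departure from any measured compound, so compound 4 is expected to give a somewhat higher number, a 2.5-fold higher number from compound 3 to compound 4 (0.40 log units; beyond the scatter), with wide uncertainty. The estimate for compound 4 is 200 nM, within 50 nM to 800 nM.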

Compound 4, half-maximal inhibitory concentration: 2800 nM
Beside the measured number, compound 4's estimate is 14-fold (1.15 log units) below it; measured number outside the range, above it.
By their numbers in this assay, from the lowest: compound 1; then compounds 3 and 2 (each within the scatter of the next); then compound 4.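

In this assay, this aromatic carbon proves far less tolerant of a change in the group itself than of a change in the alkyl group on its nitrogen: the number rises sharply on going to (dimethylamino)methyl from pentylamino (a 35-fold higher number from compound 3 to compound 4 (1.54 log units; beyond the scatter)), from methylamino (a 22-fold higher number from compound 2 to compound 4 (1.33 log units; beyond the scatter)) and from isopropylamino (a 140-fold higher number from compound 1 to compound 4 (2.15 log units; beyond the scatter)). All three steps are large, exceeding every step among the alkylamino compounds, and the entering group has no hydrogen-bond donor, whereas pentylamino has one. Nothing shown gives a reason for the loss.

The compounds leave open whether the loss goes with the missing amine hydrogen or with the carbon link to the ring, which a dimethylamino group or a methylaminomethyl group at this carbon would separate. A cyclopropylamino group would further test how the alkyl group on the nitrogen affects the number.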